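A few compounds are considered here, and "the series" means these few. Any claim that something is new, unique, unknown or untested is made for them only; others in the source may bear on it.

Compound 3 `CCOC(=O)c1cc(CCCOc2ccc(-c3noc(C(F)(F)F)n3)cc2N)on1` gives no number in an ADME assay on HeLa cells (Homo sapiens) for cytotoxicity, read by crystal violet staining, with a stated time of 72 h (on this read-out lower numbers stand for higher toxicity in this test and higher numbers for lower toxicity in this test), only a limit of > 100000 nM. Compound 4 `CN(C)C(=O)c1cc(CCCOc2ccc(-c3noc(C(F)(F)F)n3)cc2N)on1` differs from it in one place: dimethylamino in place of ethoxy on a carbonyl carbon. In words, this is dimethylamino in place of ethoxy on a carbonyl carbon, or ethoxycarbonyl to dimethylcarbamoyl when cut one bond further out.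

Going by the values given here, no measured pair isolates this change. The nearest evidence comes from two compounds that already carry the dimethylcarbamoyl group. In this assay compound 1 `COc1cc(-c2noc(C(F)(F)F)n2)ccc1OCCCc1cc(C(=O)N(C)C)no1` gives 68000 nM, and compound 2 `CN(C)C(=O)c1cc(CCCOc2ccc(-c3noc(C(F)(F)F)n3)cc2[N+](=O)[O-])on1` gives 22500 nM. Among the compounds with values here, the single measured step, a 3.0-fold lower number from compound 1 to compound 2 (0.48 log units; beyond the scatter), is modest and lies beyond the scatter, but it is a different change, nitro in place of methoxy on an aromatic carbon, so it bears only indirectly. It does show how far values can spread among compounds sharing the dimethylcarbamoyl group.

Compound 4 carries neither the methoxy nor the nitro group of those two. Taking compound 1 at 68000 nM as the closer guide, a modest move to a lower number is expected, though the true size stays open on one side. The expected step runs an at least 1.6-fold lower number from compound 3 to compound 4 (0.22 log units; that floor lies within the scatter). Compound 4 is estimated at 60000 nM, with an expected range of 22000 nM to 100000 nM.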

Compound 4, half-maximal cytotoxic concentration: 90800 nM
For compound 4 the middle estimate is 1.5-fold (0.18 log units) below the measured one; measured number inside the range.
By their numbers in this assay, from the lowest: compound 2; then compounds 1 and 4 (each within the scatter of the next). At a limit, above all of these: compound 3.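

In this assay the change on the carbonyl carbon, ethoxycarbonyl to dimethylcarbamoyl, can be read only as a floor, an at least 1.1-fold lower number from compound 3 to compound 4 (0.04 log units; that floor lies within the scatter), so with the amino group held constant its true size stays unresolved. Compound 3 stands at a limit of the assay and not at a number: the limit of > 100000 nM in this assay, at which 1 of the 4 values shown sits.

Among the dimethylcarbamoyl compounds, the substituent on the aromatic carbon now has three members, and nitro alone stands apart: amino in place of nitro gives a 4.0-fold higher number from compound 2 to compound 4 (0.61 log units; beyond the scatter), whereas amino in place of methoxy gives a 1.3-fold higher number from compound 1 to compound 4 (0.13 log units; within the scatter).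

The compounds shown leave open whether ethoxycarbonyl to dimethylcarbamoyl has any real effect in this series, and whether it would read the same with methoxy or nitro in place of amino, since every measured number for those two groups comes with the dimethylcarbamoyl group. They also leave open how a carboxylic acid or a methylamide on the same carbonyl carbon would compare, and whether a hydroxyl or a chlorine on the aromatic carbon would fall with nitro or with amino and methoxy.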